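This account rests on a few compounds, and the source may have more. Where it says the series, first, only, none or still open, it means among the compounds named here.

Measured in an ADME assay on L929 cells (Mus musculus) for cytotoxicity, read by resazurin assay, with a stated time of 72 h (a higher number here means a weaker inhibitor, a lower number a stronger inhibitor), each entry a limit of the assay and not a number:

Compound 1 `CCc1ccc(C(=O)/C=C/c2ccc3c(c2)B(O)OC3)cc1`: > 10 ug/mL
Compound 2 `O=C(/C=C/c1ccc2c(c1)B(O)OC2)c1ccccn1`: > 10 ug/mL
Compound 3 `O=C(/C=C/c1ccc2c(c1)B(O)OC2)c1ccc(Cl)c(Cl)c1`: > 10 ug/mL

Compound 2 gives > 10 ug/mL, which is a limit and not a number. Compound 1 and compound 3 stop at the same limit, so the three cannot be put in any order. None of them shows a measured strength in this assay.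

Compound 4 `Cc1cccc(C(=O)/C=C/c2ccc3c(c2)B(O)OC3)c1` has not yet been measured. It carries 3-methylphenyl in place of pyridin-2-yl on a carbonyl carbon.

Going by the values given here, no pair of measured compounds offers a step with a real size, so the data cannot size this change directly. Among the compounds with values here, the only guide is how the measured compounds sit: the limit of > 10 ug/mL in this assay, at which 3 of the 3 values shown sit. On that basis, no change beyond the scatter is expected in either direction, and compound 4 will probably read as a limit too. The expected step is a step that the limit leaves unreadable from compound 2 to compound 4. For compound 4 the estimated value is 15 ug/mL, with an expected range of 7 ug/mL to 40 ug/mL.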

Compound 4, half-maximal inhibitory concentration: 8.56 ug/mL
Estimate against measurement, compound 4: 1.8-fold (0.24 log units) above, within the range that was stated.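

In this assay, going by these compounds alone, compound 4 gives 8.56 ug/mL, the only real number in this set rather than a limit, so a change on a carbonyl carbon can bring a readable response from these cells. Putting 3-methylphenyl in place of pyridin-2-yl gives an at least 1.1-fold lower number from compound 2 to compound 4 (0.06 log units; that floor lies within the scatter); this is only a floor, so the real step may be larger, but nothing beyond the scatter is shown. The true size of the step stays unknown because the other compounds rest at one ceiling: the limit of > 10 ug/mL in this assay, at which 3 of the 4 values shown sit.

The compounds shown leave open whether the methyl group or the change from a ring holding nitrogen to a ring of carbon only matters here, and a plain phenyl group would help separate the two. They also do not show how a ring carrying an amine or a carboxylic acid would read.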